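A few compounds are considered here, and "the series" means these few. Any claim that something is new, unique, unknown or untested is made for them only; others in the source may bear on it.

In a functional assay on Shh Light II cells (Mus musculus) for inhibition, read by a luciferase reporter (on this read-out higher numbers stand for weaker inhibition and lower numbers for stronger inhibition), compound 1 (`O=C(CC1CCCCCC1)N1CCC(c2nc(-c3ccc4ccccc4n3)no2)CC1`) gives 840 nM and compound 2 (`O=C(NC1CC[S+]([O-])CC1)N1CCC(c2nc(-c3ccc4ccccc4n3)no2)CC1`) gives 850 nM. Among the compounds with values here, these are the only two numbers available, and compound 2 stands level with compound 1: the measured step is a 1.0-fold higher number from compound 1 to compound 2 (0.01 log units; within the scatter). Compound 3 (`CC(=O)N1CCC(NC(=O)N2CCC(c3nc(-c4ccc5ccccc5n4)no3)CC2)CC1`) has not yet been measured. It keeps the shared core of compound 2 and changes one group, on an amide-type nitrogen whose other neighbour is a carbonyl carbon. A 1-acetylpiperidin-4-yl group enters there: a group of 9 heavy atoms (7 carbon, 1 nitrogen, 1 oxygen; one six-membered non-aromatic ring with 1 hetero atom) in place of a group of 7 heavy atoms (5 carbon, 1 oxygen, 1 sulfur; one six-membered non-aromatic ring with 1 hetero atom), on an amide-type nitrogen. The ring stays six-membered and non-aromatic, but its hetero atom is now a nitrogen that carries the acetyl group.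

Within the data shown here, only one measured step bears on this change. Going to compound 2 (a 1.0-fold higher number from compound 1 to compound 2 (0.01 log units; within the scatter)) also exchanged a ring-bearing group, and the number did not move beyond the scatter. One step is thin evidence, so the range has to stay wide. No shift beyond the scatter is expected in this assay, in either direction. The expected step is a 1.1-fold lower number from compound 2 to compound 3 (0.03 log units; within the scatter). For compound 3 the estimated value is 800 nM, with an expected range of 350 nM to 1800 nM.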

Compound 3, half-maximal inhibitory concentration: 500 nM
Compound 3: middle estimate off by 1.6-fold (0.20 log units), on the high side, and the stated range covers the measured number.
By their numbers in this assay, from the lowest: compounds 3, 1 and 2 (each within the scatter of the next).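

In this assay, the 1-acetylpiperidin-4-yl group on the amide-type nitrogen gives a 1.7-fold lower number from compound 2 to compound 3 (0.23 log units; within the scatter), so a six-membered ring whose hetero atom is a nitrogen carrying an acetyl group reads the same, within the scatter, as the sulfur-containing ring it replaces. Set against cycloheptylmethyl on a carbonyl carbon, (1-acetylpiperidin-4-yl)amino gives a 1.7-fold lower number from compound 1 to compound 3 (0.23 log units; within the scatter), which means that three differently built ring-bearing groups now sit level at this place, and the larger group entering here, with more heavy atoms and a double bond outside aromatic rings, leaves the number inside the scatter. Nothing measured in this set gives a reason why these exchanges leave the read-out level.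

As far as these compounds go, it remains open whether this place stays as permissive for groups of another kind, such as a piperidine ring with a free amine instead of the acetyl group, a carboxylic acid on the ring, or a simple open chain with no ring at all. From the compounds shown here alone, the three compounds also share one core, so it is unknown whether the same level reading would hold on a different core.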